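The compounds below may be only part of what the source reports. "The series", "measured", "known", "first", "only" and "open" are said of these compounds alone.

Measured so far in a functional assay on MCF7 cells (Homo sapiens) for cytotoxicity, read by MTT assay, with a stated time of 72 h; on this read-out higher numbers stand for weaker inhibition and lower numbers for stronger inhibition:
compound 1 `Cc1ccc(-c2ccnc(C(=O)Nc3ccc(Oc4ccnc5[nH]ccc45)cc3)c2)cc1`: > 10000 nM, a limit of the assay, not a number.
compound 2 `O=C(Nc1ccc(Oc2ccnc3[nH]ccc23)cc1)c1cc(-c2ccccc2)ccn1`: 3750 nM.

Compound 2 holds the only number shown. The value of compound 1 is the limit of > 10000 nM in this assay, at which 1 of the 2 values shown sits. Going by the values given here, the single measured step, an at least 2.6-fold lower number from compound 1 to compound 2 (0.42 log units; beyond the scatter), concerns a methyl group removed from an aromatic carbon and says nothing about a fluorine entering. Compound 3 `O=C(Nc1ccc(Oc2ccnc3[nH]ccc23)c(F)c1)c1cc(-c2ccccc2)ccn1` differs from compound 2 by fluoro in place of hydrogen on an aromatic carbon. Among the compounds with values here, no measured step bears on this change, so in this assay no step beyond the scatter is expected, a 1.2-fold lower number from compound 2 to compound 3 (0.07 log units; within the scatter). Compound 3 is therefore estimated at 3200 nM, in the range 1200 nM to 8500 nM.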

Compound 3, half-maximal inhibitory concentration: > 10000 nM
Compound 3 gave a limit, no number (the forecaster's own chance of this, stated with the estimate: 15%); middle value at least 3.1-fold (0.49 log units) away from the limit.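

In this assay fluoro in place of hydrogen, on an aromatic carbon ortho to a large group and meta to a large group, gives an at least 2.6-fold higher number from compound 2 to compound 3 (0.42 log units; beyond the scatter) and so this position is sensitive to even this single-atom change. Compound 3 gives > 10000 nM as a limit of the assay, not a number. A measured number in this series now rests on compound 2 alone, with the others at the limit: the limit of > 10000 nM in this assay, at which 2 of the 3 values shown sit.

Open, on these data alone, is whether chloro, methoxy or an amine on this carbon would match fluoro. Also open, as far as these compounds go, is whether fluoro elsewhere on this ring would give a number at all.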